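A few compounds are considered here, and "the series" means these few. Any claim that something is new, unique, unknown or untested is made for them only; others in the source may bear on it.

- Compound 1 `O=C1/C(=C/c2cccnc2)CNC/C1=C\c1ccccc1F`: > 20000 nM, a limit of the assay
- Compound 2 `O=C1/C(=C/c2cccnc2)CN(S(=O)(=O)c2ccccc2)C/C1=C\c1ccccc1F`: 19100 nM
- Compound 3 `O=C1/C(=C/c2cccnc2)CN(S(=O)(=O)c2ccc(C(F)(F)F)cc2)C/C1=C\c1ccccc1F`: 7900 nM

These results come from a functional assay on SMMC-7721 cells (Homo sapiens) for cytotoxicity, read by MTT assay, with a stated time of 24 h; on this read-out lower numbers stand for stronger inhibition and higher numbers for weaker inhibition. Of the two true numbers, compound 3 holds the lower, 7900 nM. Compound 4 `O=C1/C(=C/c2cccnc2)CN(S(=O)(=O)c2ccc(F)cc2)C/C1=C\c1ccccc1F` has fluoro in place of trifluoromethyl on an aromatic carbon, para to a large group: fluoro in place of trifluoromethyl on an aromatic carbon. The best guide is a 2.4-fold lower number from compound 2 to compound 3 (0.38 log units; beyond the scatter), where adding trifluoromethyl in place of hydrogen lowered the number modestly. The other measured step, an at least 1.0-fold lower number from compound 1 to compound 2 (0.01 log units; that floor lies within the scatter), offers little guidance. Losing the trifluoromethyl may undo part of that modest drop, so a small rise is expected, possibly not beyond the scatter. The estimated value for compound 4 is 11000 nM, with an expected range of 5500 nM to 20000 nM. That would be an expected 1.4-fold higher number from compound 3 to compound 4 (0.14 log units; within the scatter).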

Compound 4, half-maximal inhibitory concentration: 9900 nM
Beside the measured number, compound 4's estimate is 1.1-fold (0.05 log units) above it; the measured number falls inside the stated range.
By their numbers in this assay, from the lowest: compounds 3, 4 and 2 (each within the scatter of the next, the first and the last beyond it). At a limit, above all of these: compound 1.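

Fluoro in place of trifluoromethyl on an aromatic carbon, para to a large group, gives a 1.3-fold higher number from compound 3 to compound 4 (0.10 log units; within the scatter), so the two groups cannot be told apart at this position. Fluoro in place of hydrogen there gives a 1.9-fold lower number from compound 2 to compound 4 (0.29 log units; within the scatter), so, unlike trifluoromethyl, fluoro does not clearly separate from hydrogen. The step of an at least 2.0-fold lower number from compound 1 to compound 4 (0.30 log units; that floor lies within the scatter) is only a floor, because its starting value is a limit: the limit of > 20000 nM in this assay, at which 1 of the 4 values shown sits.

From the compounds shown here alone, whether an amine, a methoxy group or a carboxylic acid at this position would shift the number beyond the scatter stays open.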